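Compound 2 to compound 4: adding fluoro to the core

This account rests on a few compounds, and the source may have more. Where it says the series, first, only, none or still open, it means among the compounds named here.

compound 1 `O=C1Nc2ccccc2/C1=C/c1ccc(-c2cn(-c3ccccc3Cl)nn2)cc1` | > 20000 nM (a limit)
compound 2 `N#Cc1ccc(-n2cc(-c3ccc(C=C4C(=O)Nc5ccccc54)cc3)nn2)cc1` | 15800 nM
compound 3 `Cc1cccc(-n2cc(-c3ccc(/C=C4\C(=O)Nc5ccc(F)cc54)cc3)nn2)c1` | 7320 nM

In a functional assay on HT-29 cells (Homo sapiens) for inhibition, read by CCK-8 assay, with a stated time of 24 h (a higher number here means a weaker inhibitor, a lower number a stronger inhibitor), compound 1 gives > 20000 nM as a limit of the assay and not a number. Of the two numeric values, compound 2 stands highest at 15800 nM and the nearest is compound 3 at 7320 nM with a gap beyond the usual scatter.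

Compound 4 `N#Cc1ccc(-n2cc(-c3ccc(C=C4C(=O)Nc5ccc(F)cc54)cc3)nn2)cc1` departs from compound 2 by a single change fluoro in place of hydrogen on an aromatic carbon with fluoro in place of hydrogen on an aromatic carbon of a six-membered aromatic ring of carbon only, part of a fused system of two rings. For the measured compounds named here, no measured pair differs in one place only, so this assay offers no direct precedent for this step. Compound 3 at 7320 nM carries the same fluoro but also differs from compound 2 in a second place, which makes it a weak hint only. A small move towards a lower number is therefore expected, possibly none beyond the scatter. The estimated change a 1.6-fold lower number from compound 2 to compound 4 (0.20 log units; within the scatter) rests on that hint alone. For compound 4 the expected value is 10000 nM with an estimated range from 4500 nM to 20000 nM in this series.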

Compound 4, half-maximal inhibitory concentration: 20000 nM
Beside the measured number, compound 4's estimate is 2.0-fold (0.30 log units) below it; the range from low to high includes it.
By their numbers in this assay, from the lowest: compound 3; then compounds 2 and 4 (each within the scatter of the next).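

In this assay, for the compounds shown here, this is the first step that isolates one change: fluoro in place of hydrogen on an aromatic carbon of the fused system of two rings, meta to a fused ring and para to a fused ring, gives a 1.3-fold higher number from compound 2 to compound 4 (0.10 log units; within the scatter). With the nitrile-bearing ring held constant, this position therefore tolerates the swap with no change that can be told from the scatter. The same fluoro in compound 3, which has a value of 7320 nM, thus gains no support here as the source of that value, and compounds 2 and 4 both remain weak enough that a further upward move at this position would have little room to show: the limit of > 20000 nM in this assay, at which 1 of the 4 values shown sits.

On these data alone, what remains open is whether a different group at this position, such as a methoxy group, an amine or a carboxylic acid, would move the number beyond the scatter. It is also unresolved whether fluoro gives the same small step when the nitrile is replaced by another group, since no pair with and without fluoro on any other ring is shown.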